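A few compounds are considered here, and "the series" means these few. Any claim that something is new, unique, unknown or untested is made for them only; others in the source may bear on it.

Measured compounds in a functional assay on HOP-62 cells (Homo sapiens) for cytotoxicity, read by sulforhodamine B assay, with a stated time of 48 h, tested at 10 uM; a lower number here means a stronger effect, a higher number a weaker effect of the compound at the concentration tested:

compound 1 `COc1cc(-c2cc(/C=C/C(=O)c3ccc(Cl)c(Cl)c3)[nH]n2)cc(OC)c1OC`, -9%
compound 2 `COc1ccc(-c2cc(/C=C/C(=O)c3ccc(N)cc3)[nH]n2)cc1OC`, -1%
compound 3 `COc1ccc(-c2cc(/C=C/C(=O)c3cc(OC)c(OC)c(OC)c3)[nH]n2)cc1OC`, -57%

Among these three numbers compound 1 stands second highest. Its nearest neighbour is compound 2, whose value lies only a few points higher and within the scatter of this assay, so the two cannot be told apart. The furthest is compound 3, whose value lies well below that of compound 1, a gap that is beyond the scatter.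

The step considered here leads from compound 1 to compound 4 `COc1ccc(C(=O)/C=C/c2cc(-c3cc(OC)c(OC)c(OC)c3)n[nH]2)cc1OC`, which has not yet been measured. The change is 3,4-dimethoxyphenyl in place of 3,4-dichlorophenyl on a carbonyl carbon. No step between measured compounds that differ in one place is at hand, so the size of this step cannot be read from a shown pair. Among the compounds with values here, the only measured compound with a methoxy-bearing ring on the carbonyl carbon is compound 3, which gives -57%, and this is the one indication of what such a ring may do here.

On that basis compound 4 is expected to give a lower number than compound 1, with the step of a number 21 percentage points lower from compound 1 to compound 4 (beyond the scatter) beyond the scatter. The estimate for compound 4 is -30%, with a range from -60% to 0%.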

Compound 4, a percentage reported as activity, at one concentration (the size of the read-out at that concentration, not a potency): -97%
Beside the measured number, compound 4's estimate is 67 percentage points above it; the whole stated range lies above it.
By their numbers in this assay, from the lowest: compound 4; then compound 3; then compounds 1 and 2 (each within the scatter of the next).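

With 3,4-dimethoxyphenyl in place of 3,4-dichlorophenyl on a carbonyl carbon, the read-out in this assay shows a number 88 percentage points lower from compound 1 to compound 4 (beyond the scatter) and this gives the first direct view of this position. Within the data shown here, the rest of the core of compound 1 stays unchanged in this pair, so the large shift belongs to this single exchange, which the earlier compounds, differing in more than one place, could not show. Nothing measured here explains the size of this step.

Going by these compounds, it remains open whether a single methoxy group on this phenyl ring would give a similar read-out, or whether one chlorine and one methoxy group together would. On these data alone, how a dimethylamino group or a carboxylic acid on the same ring would behave also remains unknown.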